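The compounds below may be only part of what the source reports. "The series", "measured", "known", "first", "only" and "open" are said of these compounds alone.

Compound 1 `C=C1CC(CCCCCCCCCCCCC)OC1=O`: 3900 nM
Compound 2 `C=C1C(=O)OC(CCCCCCCCCCCCC)C1CCc1ccccc1`: 3300 nM

In a functional assay on A375M cells (Homo sapiens) for cytotoxicity, read by MTT assay, with a stated time of 4 days (on this read-out lower numbers stand for stronger inhibition and higher numbers for weaker inhibition), compound 2 at 3300 nM lies within the scatter of compound 1 at 3900 nM. Compound 3 `C=C1C(=O)OC(CCCC)C1CCc1ccccc1` is about to be tested, and it differs from compound 2 in its long chain: hydrogen in place of nonyl on a saturated chain carbon, four bonds along the chain from a saturated ring carbon. For the measured compounds named here, only one measured step exists, a 1.2-fold lower number from compound 1 to compound 2 (0.07 log units; within the scatter). It placed phenethyl on a saturated ring carbon and left the chain untouched, so it bears on this change only indirectly. Going by the values given here, no measured pair shows what removing nonyl does in this assay. Starting from compound 2 at 3300 nM, a modest move to a higher number is expected, with wide uncertainty. The estimated step is a 2.4-fold higher number from compound 2 to compound 3 (0.38 log units; beyond the scatter). Compound 3 is estimated at 8000 nM, with an expected range of 2500 nM to 25000 nM.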

Compound 3, half-maximal inhibitory concentration: 5500 nM
Compound 3: middle estimate off by 1.5-fold (0.16 log units), on the high side; the range from low to high includes it.
By their numbers in this assay, from the lowest: compounds 2, 1 and 3 (each within the scatter of the next).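

Hydrogen in place of nonyl on a saturated chain carbon, four bonds along the chain from a saturated ring carbon, gives a 1.7-fold higher number from compound 2 to compound 3 (0.22 log units; within the scatter) in this assay and so stays within the scatter. For the compounds shown here, this is the first measured change to the long chain, as the earlier step concerned only the ring carbon that carries phenethyl. With phenethyl in place, compound 3 therefore holds a value comparable to that of compound 2 without the nonyl group, although no measurement here explains this tolerance.

The compounds shown leave open whether the nonyl group can be lost equally well from a compound lacking phenethyl. They also leave open whether an amine, a carboxylic acid or a longer chain in place of the nonyl would give a step beyond the scatter.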